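The source may report more compounds than this note shows. Statements on the series, on what has been measured and on what is new or still open speak of the compounds shown alone.

Compound 3 `COc1ncc(C(C)(C)C)cc1CN[C@H]1[C@H](C(C)(C)C)[C@@H](C(=O)O)N(C(=O)C2CCCCC2)[C@H]1c1ccccc1` carries a tert-butyl group on a six-membered aromatic ring that holds one nitrogen. For the measured compounds named here, in an assay on HBE cells for positive allosteric modulation of Cystic fibrosis transmembrane conductance regulator variant F508del (Homo sapiens) (on this read-out lower numbers stand for smaller maximal responses and higher numbers for larger maximal responses), compound 3 gives 114%, the lowest of the three numbers measured so far. Compound 1 `COc1ccc(C(C)C)cc1CN[C@H]1[C@H](C(C)(C)C)[C@@H](C(=O)O)N(C(=O)C2CCCCC2)[C@H]1c1ccccc1` gives 191%, and compound 2 `COc1ccc(C(C)(C)C)cc1CN[C@H]1[C@H](C(C)(C)C)[C@@H](C(=O)O)N(C(=O)C2CCCCC2)[C@H]1c1ccccc1` gives 195%; in both of these the corresponding ring is built of carbon only. The step of a number 77 percentage points lower from compound 1 to compound 3 (beyond the scatter) and the step of a number 81 percentage points lower from compound 2 to compound 3 (beyond the scatter) are both large, whereas a number 4 percentage points higher from compound 1 to compound 2 (within the scatter) stays within the scatter. Compound 4 `COc1ncc(C2CCC2)cc1CN[C@H]1[C@H](C(C)(C)C)[C@@H](C(=O)O)N(C(=O)C2CCCCC2)[C@H]1c1ccccc1` differs from compound 3 by cyclobutyl in place of tert-butyl on an aromatic carbon. Going by the values given here, the only measured step that alters this same group, a number 4 percentage points higher from compound 1 to compound 2 (within the scatter), stayed within the scatter. No step beyond the scatter is expected, and the estimated step is a number 1 percentage points higher from compound 3 to compound 4 (within the scatter). For compound 4 the expected value in this assay is therefore 115%, with a plausible span from 85% to 150%.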

Compound 4, largest response reached (reported as percent of maximum), in percent of the reference or control that the assay uses: 106%
Compound 4: the middle estimate sits 9 percentage points above what was measured, and the stated range covers the measured number.
By their numbers in this assay, from the lowest: compounds 4 and 3 (each within the scatter of the next); then compounds 1 and 2 (each within the scatter of the next).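

In this assay the tert-butyl group at this ring carbon, para to a methoxy group, can give way to cyclobutyl with only a number 8 percentage points lower from compound 3 to compound 4 (within the scatter) and so a closed ring of the same heavy-atom count does not separate the two compounds on the ring that holds a nitrogen, whereas the earlier swap of groups at this place involved only a ring of carbon only. With cyclobutyl in place the gap to the carbon-only compounds remains large, at a number 89 percentage points lower from compound 2 to compound 4 (beyond the scatter) and a number 85 percentage points lower from compound 1 to compound 4 (beyond the scatter) and so this change of group does not close that gap. No measurement available here explains these numbers.

From the compounds shown here alone, it remains open whether cyclobutyl would fare as well on the ring of carbon only. Also open, going by these compounds, is how a cyclopropyl group, a trifluoromethyl group or an amine would read at this position.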